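This account rests on a few compounds, and the source may have more. Where it says the series, first, only, none or still open, it means among the compounds named here.

In an ADME assay on Vero cells (Chlorocebus sabaeus) for cytotoxicity (on this read-out higher numbers stand for lower toxicity in this test and lower numbers for higher toxicity in this test), compound 1 `CC(C)(C)[Si](C)(C)OC[C@H]1O[C@@H](n2cnc3c(N)ncnc32)[C@H](O[Si](C)(C)C(C)(C)C)[C@@H]1C#N` gives 10 ug/mL. Compound 2 `Cc1cn([C@H]2C[C@@H](C#N)[C@@H](CO)O2)c(=O)[nH]c1=O` reaches only a limit of the test in this assay, reported as > 400 ug/mL, so no number is known for it. Compound 2 thus stands at the limit of > 400 ug/mL in this assay, at which 1 of the 2 values shown sits. Compound 3 `Cc1cn([C@H]2C[C@H](C#N)[C@@H](CO)O2)c(=O)[nH]c1=O` differs from compound 2 only in configuration: the two compounds have the same atoms and bonds and differ only in configuration as drawn: 1 of 3 stereo elements differ; a stereocentre at a saturated ring carbon is drawn S in compound 2 and R in compound 3. With no measured step of this kind in hand, the change is expected to shift the read-out in this assay by no more than the usual scatter, a step of a number no higher from compound 2 to compound 3 (the limit leaves the size open) in either direction. Compound 3 is therefore estimated at 400 ug/mL, within 150 ug/mL to 400 ug/mL, and is expected most likely to be reported again only as a limit.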

Compound 3, minimum cytotoxic concentration: > 10 ug/mL
Compound 3: no number, only a limit; the forecaster's own chance of this, stated with the estimate: 80%; the middle value does not contradict the limit.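

Compound 2 and compound 3 are both reported only as limits in this assay, so no step can be read between them. On these data alone, whether the configuration at that saturated ring carbon shifts the read-out at all stays open.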